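From Isopropoxycarbonyl to Benzyl: Expected Stability

A few compounds are considered here, and "the series" means these few. Any claim that something is new, unique, unknown or untested is made for them only; others in the source may bear on it.

Compound 1, `CCCCCNc1nc(Nc2ccc([N+](=O)[O-])cc2)nc(OCC(F)(F)F)n1`: 74%
Compound 2, `CC(C)OC(=O)NCCS(=O)(=O)NC(=O)c1ccc(Nc2nc(NC3(c4ccc(Cl)cc4)CC3)nc(OCC(F)(F)F)n2)cc1`: 100%

In an ADME assay on microsomes from liver (Homo sapiens) for metabolic stability, with a stated time of 10 min (on this read-out higher numbers stand for a more stable compound and lower numbers for a less stable compound), compound 2 gives 100%, the higher of the two numbers shown, while compound 1 gives 74%, a gap that lies beyond the usual scatter. Compound 3, `O=C(NS(=O)(=O)CCNCc1ccccc1)c1ccc(Nc2nc(NC3(c4ccc(Cl)cc4)CC3)nc(OCC(F)(F)F)n2)cc1`, differs from compound 2 in one place: benzyl in place of isopropoxycarbonyl on an amine nitrogen. Among the measured compounds shown here, no measured pair shows this exchange, so its effect is open. A moderate fall in this assay is expected, beyond the scatter but leaving compound 3 fairly stable. Compound 3 is therefore estimated at 75%, ranging from 50% to 100%. The expected step is a number 25 percentage points lower from compound 2 to compound 3 (beyond the scatter).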

Compound 3, percent of the compound remaining: 99%
The estimate for compound 3 lay 24 percentage points below the measured number; measured number inside the range.
By their numbers in this assay, from the lowest: compound 1; then compounds 3 and 2 (each within the scatter of the next).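

In this assay the exchange of isopropoxycarbonyl for benzyl on the amine nitrogen gives a number 1 percentage points lower from compound 2 to compound 3 (within the scatter) and so leaves the read-out within the usual scatter. This position therefore accepts a group with a six-membered aromatic ring in place of one with a carbonyl, with no loss of stability in this test. Nothing available explains why the two compounds read alike.

Still open, on these data alone, is how the free amine, with neither group on that nitrogen, would read. An acetyl group or a longer chain such as phenethyl at this place also remains to be seen.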